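Dimethylamino in Place of Acetyl on the Shared Core

The compounds below may be only part of what the source reports. "The series", "measured", "known", "first", "only" and "open" are said of these compounds alone.

Going by the values given here, compound 1 `COc1cc(C)cc(-c2c(-c3ccnc(-c4ccc(C(C)=O)cc4)c3)cnn2CC#N)c1` is one of three compounds measured in a functional assay on OVCAR-5 cells (Homo sapiens) for cytotoxicity, read by sulforhodamine B assay, with a stated time of 48 h, tested at 0.001 uM; a higher number here means a weaker effect of the compound at the concentration tested, a lower number a stronger effect. In this assay compound 1 gives 85%, the second highest of the three numbers. Compound 2 `Cc1cc(O)cc(-c2nn(CC#N)cc2-c2ccnc(-c3ccc(Oc4ccccc4)cc3)c2)c1` gives 72%, and compound 3 `Cc1cc(O)cc(-c2nn(CC#N)cc2-c2ccnc(-c3ccc(N(C)C)cc3)c2)c1` gives 96%; compound 1 stands between them, beyond the scatter from each.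

Compound 4 `COc1cc(C)cc(-c2c(-c3ccnc(-c4ccc(N(C)C)cc4)c3)cnn2CC#N)c1` differs from compound 1 by one change: dimethylamino in place of acetyl on an aromatic carbon. Among the compounds with values here, the one measured step that bears on this is a number 24 percentage points higher from compound 2 to compound 3 (beyond the scatter), which brings in the same dimethylamino group at the same place on the shared core, though the group it replaces there is phenoxy rather than acetyl. Since compound 3, the measured compound carrying dimethylamino, stands at 96%, a rise of the same kind is expected here, bounded by how little room compound 1 leaves toward the top of the percentage scale. Compound 4 is therefore expected to give 95%, within a range of 84% to 102%. The expected step is a number 10 percentage points higher from compound 1 to compound 4 (within the scatter).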

Compound 4, a percentage reported as activity, at one concentration (the size of the read-out at that concentration, not a potency): 90%
The estimate for compound 4 lay 5 percentage points above the measured number; measured number inside the range.
By their numbers in this assay, from the lowest: compound 2; then compounds 1, 4 and 3 (each within the scatter of the next, the first and the last beyond it).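

In this assay, dimethylamino in place of acetyl on the aromatic carbon para to a large group gives a number 5 percentage points higher from compound 1 to compound 4 (within the scatter) and so does not separate these two groups at this place on the core of compound 1. The earlier step at the same place, a number 24 percentage points higher from compound 2 to compound 3 (beyond the scatter), did separate dimethylamino from phenoxy, so the entry of dimethylamino does not give a change beyond the scatter in both pairs. No measurement at hand offers an explanation for this difference between the pairs.

On these data alone, whether phenoxy would also lower the number on the core of compound 1 remains open. So does whether a carboxylic acid or a morpholine at this place would give a number beyond the scatter of those for acetyl and dimethylamino.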